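Cytotoxicity notes: hydroxymethyl for methylsulfonyl on two cores

This account rests on a few compounds, and the source may have more. Where it says the series, first, only, none or still open, it means among the compounds named here.

Compound 1 `CS(=O)(=O)CCCn1c(Cn2c(=O)n(C3CC3)c3ccncc32)cc2cc(Cl)ccc21` and compound 2 `O=c1n(Cc2cc3cc(Cl)ccc3n2CCCCO)c2cnccc2n1C1CC1` share one core; compound 3 `CS(=O)(=O)CCCn1c(Cn2c(=O)n(C3CC3)c3ccncc32)nc2nc(Cl)ccc21` and compound 4 `O=c1n(Cc2nc3nc(Cl)ccc3n2CCCCO)c2cnccc2n1C1CC1` share another. The difference between the two cores is not broken down here. In an ADME assay on HeLa cells (Homo sapiens) for cytotoxicity, read by ATP content, with a stated time of 3 days (a lower number here means that less compound is tolerated, a higher number that more compound is tolerated), compound 1 reports only a limit, > 50000 nM. Compound 2 likewise reports only a limit in this assay, > 50000 nM. Compound 3 also reports only a limit in this assay, > 50000 nM. The change from compound 1 to compound 2 is hydroxymethyl in place of methylsulfonyl on a saturated chain carbon, three bonds along the chain from an aromatic nitrogen. Its step, a step that the two limits leave unreadable from compound 1 to compound 2, cannot be sized because of the limit of > 50000 nM in this assay, at which 3 of the 3 values shown sit. The same kind of change recurs on the other core: hydroxymethyl in place of methylsulfonyl on a saturated chain carbon, three bonds along the chain from an aromatic nitrogen, with the place described in identical words. Compound 4 is expected to tolerate the same kind of exposure, with an estimated 60000 nM in this assay. For compound 4 the range expected runs from 30000 nM to 200000 nM. The expected step that the limit leaves unreadable from compound 3 to compound 4 rests on (the limit of > 50000 nM in this assay, at which 3 of the 3 values shown sit), so compound 4 will most likely report only a limit again.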

Compound 4, half-maximal cytotoxic concentration: > 50000 nM
Compound 4 ended at the assay's limit; the forecaster's own chance of this, stated with the estimate: 85%; the middle value is on the limit's open side.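

No new step can be read from compound 3 to compound 4 in this assay, because both compounds report only a limit: the limit of > 50000 nM in this assay, at which 4 of the 4 values shown sit.

The compounds shown leave open how much compound the cells tolerate in this assay for any of the four, and whether hydroxymethyl in place of methylsulfonyl changes that on either core.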